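This account rests on a few compounds, and the source may have more. Where it says the series, first, only, none or still open, it means among the compounds named here.

Measured compounds in a functional assay for antagonist activity at transient receptor potential cation channel subfamily V member 1 (Rattus norvegicus); a lower number here means a stronger inhibitor, a higher number a weaker inhibitor:
- compound 1, `Cc1cccnc1-c1ccc(C(=O)Nc2ccc(C(C)(C)C)cc2)cc1`: 9 nM
- compound 2, `CC(C)(C)c1ccc(NC(=O)c2ccc(-c3ccccn3)cc2)cc1`: 8 nM
- compound 3, `CCCNc1cccnc1-c1ccc(C(=O)Nc2ccc(C(C)(C)C)cc2)cc1`: 37 nM

Of these three, compound 3 carries the highest number in this assay; the step of a 4.1-fold higher number from compound 1 to compound 3 (0.61 log units; beyond the scatter) and the step of a 4.6-fold higher number from compound 2 to compound 3 (0.67 log units; beyond the scatter) both lie beyond the scatter, while the step of a 1.1-fold lower number from compound 1 to compound 2 (0.05 log units; within the scatter) does not, so compounds 1 and 2 cannot be ordered against each other.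

Compound 4, `CC(C)(C)c1ccc(NC(=O)c2ccc(-c3ncccc3NC3CCCC3)cc2)cc1`, is not yet measured. It differs from compound 3 in one place: cyclopentyl in place of propyl on a nitrogen on an aromatic ring. Going by the values given here, no measured pair shows this exchange of one alkyl for another on the amino nitrogen. The two steps that reach compound 3 show that attaching propylamino at this aromatic carbon raised the number modestly, but they say nothing about the effect of enlarging the alkyl on that nitrogen. The step of a 1.1-fold higher number from compound 3 to compound 4 (0.03 log units; within the scatter) is therefore expected to be small, with no confident direction. Compound 4 is estimated at 40 nM in this assay, with a range from 12 nM to 130 nM.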

Compound 4, half-maximal inhibitory concentration: 44 nM
Compound 4: middle estimate off by 1.1-fold (0.04 log units), on the low side; low and high end bracket the measured number.
By their numbers in this assay, from the lowest: compounds 2 and 1 (each within the scatter of the next); then compounds 3 and 4 (each within the scatter of the next).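

In this assay, the exchange of cyclopentyl for propyl on a nitrogen on an aromatic ring, the first alkyl-for-alkyl exchange seen at this nitrogen, gives a 1.2-fold higher number from compound 3 to compound 4 (0.08 log units; within the scatter), so the ring and the added carbon atoms leave no resolved change here. Against the compounds without an amino group, cyclopentylamino behaves as propylamino did, with a 5.5-fold higher number from compound 2 to compound 4 (0.74 log units; beyond the scatter) and a 4.9-fold higher number from compound 1 to compound 4 (0.69 log units; beyond the scatter), so with these two groups the higher number holds for both alkyls tried on the nitrogen. Nothing measured is at hand to explain these numbers.

The compounds shown leave open whether a plain amino group or methylamino at this aromatic carbon would also raise the number. They also leave open whether a longer chain or a much larger ring, such as cyclohexyl, on the nitrogen would stay as close to propyl.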